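Swapping the Aryl Group on a Weakly Active Scaffold

The compounds below may be only part of what the source reports. "The series", "measured", "known", "first", "only" and "open" are said of these compounds alone.

Compound 1 `CCOC(=O)C1=Cc2ccccc2OC1(OCc1cn(-c2cccc(OC)c2)nn1)C(F)(F)F` carries a 3-methoxyphenyl on an aromatic nitrogen. In a functional assay on DU-145 cells (Homo sapiens) for inhibition, read by MTT assay, with a stated time of 24 h (a higher number here means a weaker inhibitor, a lower number a stronger inhibitor), compound 1 gives only a limit of the assay, > 150000 nM, so its true value is not known as a number; it sits at the limit of > 150000 nM in this assay, at which 1 of the 3 values shown sits. Two relatives were measured as numbers. For the measured compounds named here, compound 2 `O=C(O)C1=Cc2ccccc2OC1(OCc1cc(-c2ccc3ccccc3c2)no1)C(F)(F)F` gives 141000 nM in this assay, and compound 3 `CCOC(=O)C1=Cc2ccccc2OC1(OCc1cc(-c2ccc(F)cc2)no1)C(F)(F)F` gives 53500 nM; all three are weak inhibitors, and no single-point step between measured compounds is available, so only their bare values can be set side by side.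

Compound 4 `CCOC(=O)C1=Cc2ccccc2OC1(OCc1cn(-c2ccc(C)cc2)nn1)C(F)(F)F` has not yet been measured. It differs from compound 1 in one place: 4-methylphenyl in place of 3-methoxyphenyl on an aromatic nitrogen. A methyl replaces a methoxy on the ring that hangs from the aromatic nitrogen. Going by the values given here, because compound 1 stands only at the limit > 150000 nM, no measured step exists to lean on. The expected step of a number no higher from compound 1 to compound 4 (the limit leaves the size open) is none beyond the usual scatter. Compound 4 is therefore estimated to give about 150000 nM in this assay, within a range from 60000 nM to 400000 nM, with a fair chance that only a limit is reported again.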

Compound 4, half-maximal inhibitory concentration: 30200 nM
Beside the measured number, compound 4's estimate is 5.0-fold (0.70 log units) above it, and the stated range ends above it.
By their numbers in this assay, from the lowest: compounds 4 and 3 (each within the scatter of the next); then compound 2. At a limit, above all of these: compound 1.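

Placing 4-methylphenyl where 3-methoxyphenyl stood on the aromatic nitrogen gives an at least 4.9-fold lower number from compound 1 to compound 4 (0.69 log units; beyond the scatter) in this assay, which is the first readable step among these compounds. It shows that the shared core does not set the result alone: the aryl group at this position can shift the read-out beyond the usual scatter, although compound 4, at 30200 nM, is still a weak inhibitor. Compound 1 stands at a limit, so the step gives only its smallest possible size, and the true change may be larger: the limit of > 150000 nM in this assay, at which 1 of the 4 values shown sits.

This one swap changes both the group on the phenyl ring and where that group sits, so the compounds shown cannot tell which of the two matters, or whether the methoxy oxygen has any part in the result. They also leave open how the read-out would respond to a phenyl ring carrying an amine or a longer chain at this position, and whether any such ring would bring the number down further.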